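The compounds below may be only part of what the source reports. "The series", "measured", "known", "first", "only" and "open" are said of these compounds alone.

Within the data shown here, compound 1 `C=CCOc1cc(OC)c(C(=O)/C=C/c2ccco2)c(OCC=C)c1` is the one member of this small set with a number in hand: in an ADME assay on Vero cells (Chlorocebus sabaeus) for cytotoxicity, read by MTT assay (a higher number here means a weaker inhibitor, a lower number a stronger inhibitor), compound 1 gives 191000 nM. Compound 2 `C=CCOc1cc(OC)c(C(=O)/C=C/c2ccc[nH]2)c(OCC=C)c1` carries 1H-pyrrol-2-yl on a double-bonded chain carbon bound to a double-bonded chain carbon, and in this assay compound 2 shows "not determined" (no result reported), no result having been reported; so compound 2 stands nowhere on the scale and gives no anchor of its own. Compound 3 `C=CCOc1cc(OC)c(C(=O)/C=C/c2cccc(OC)c2)c(OCC=C)c1` has not yet been measured in this assay. It differs from compound 2 in one place: 3-methoxyphenyl in place of 1H-pyrrol-2-yl on a double-bonded chain carbon bound to a double-bonded chain carbon.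

Among the measured compounds shown here, no measured pair in this set differs in just one place, so no measured step is available to set the size of this one. For the measured compounds named here, with only compound 1 measured, the account expects the change from compound 2 to compound 3 to produce no step in this assay beyond the usual scatter, in neither direction. Compound 3 is therefore estimated to give about 180000 nM in this assay, with an expected range from 60000 nM to 500000 nM, because compound 1 gives 191000 nM and nothing measured points away from it.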

Compound 3, half-maximal inhibitory concentration: 142000 nM
The estimate for compound 3 lay 1.3-fold (0.10 log units) above the measured number; measured number inside the range.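

In this assay, the place on a double-bonded chain carbon bound to a double-bonded chain carbon now has its first readable step, a 1.3-fold lower number from compound 1 to compound 3 (0.13 log units; within the scatter), with 3-methoxyphenyl in place of furan-2-yl. This shows that a five-membered aromatic ring and a six-membered aromatic ring of carbon only, the latter bearing a methoxy group, can occupy this place on the shared core without the number leaving the scatter, although this rests on a single pair; the step from compound 2 to compound 3 cannot be read, as compound 2 has no reported result. Nothing at hand gives a reason for the closeness of these two numbers.

The compounds shown leave open whether an unsubstituted phenyl, or a 3-methoxyphenyl with the methoxy group replaced by a longer chain such as butoxy, would also stay within the scatter in this assay. They also leave open whether a carboxylic acid or an aminomethyl group on the ring at this place would shift the number beyond the scatter in either direction.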